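A few compounds are considered here, and "the series" means these few. Any claim that something is new, unique, unknown or untested is made for them only; others in the source may bear on it.

Measured so far in an ADME assay on HepG2 2.2.15 cells (Homo sapiens) for cytotoxicity; a higher number here means that more compound is tolerated, a lower number that less compound is tolerated:
- compound 1 `O=C(OCCc1c(-c2ccccc2Cl)c2cc(Cl)ccc2[nH]c1=O)C1CCCC1`: 46000 nM
- compound 2 `O=C(COc1ccccc1)OCCc1c(-c2ccccc2Cl)c2cc(Cl)ccc2[nH]c1=O`: 81000 nM
- compound 3 `O=C(/C=C/c1ccccc1)OCCc1c(-c2ccccc2Cl)c2cc(Cl)ccc2[nH]c1=O`: 230000 nM

Compound 3 has the highest number of the three. Both a 2.8-fold higher number from compound 2 to compound 3 (0.45 log units; beyond the scatter) and a 5.0-fold higher number from compound 1 to compound 3 (0.70 log units; beyond the scatter) lie beyond the scatter, whereas a 1.8-fold higher number from compound 1 to compound 2 (0.25 log units; within the scatter) stays within it.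

Next in the series is compound 4 `O=C(/C=C/c1cccc(C(F)(F)F)c1)OCCc1c(-c2ccccc2Cl)c2cc(Cl)ccc2[nH]c1=O`. The change is trifluoromethyl in place of hydrogen on an aromatic carbon, meta to a large group. Cut one bond further out, this reads 2-phenylethenyl to 2-(3-(trifluoromethyl)phenyl)ethenyl.

Among the compounds with values here, no measured step alters a substituent on that aromatic ring, so the evidence is indirect. The three steps exchange the whole group on the carbonyl carbon, and the largest is the modest 5.0-fold higher number from compound 1 to compound 3 (0.70 log units; beyond the scatter). A change confined to one aromatic carbon is therefore not expected to exceed that size in this assay. Compound 3 stands at the top of this small set, so a slight move back towards compound 2 at 81000 nM is expected rather than a further rise, though the data cannot settle the direction. The expected step is a 1.8-fold lower number from compound 3 to compound 4 (0.25 log units; within the scatter).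

The estimate for compound 4 is 130000 nM, with an expected range from 50000 nM to 300000 nM.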

Compound 4, half-maximal cytotoxic concentration: > 1400000 nM
Compound 4: no number, only a limit; the forecaster's own chance of this, stated with the estimate: 15%; middle value at least 10-fold (1.03 log units) away from the limit.
By their numbers in this assay, from the lowest: compounds 1 and 2 (each within the scatter of the next); then compound 3. At a limit, above all of these: compound 4.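

In this assay, trifluoromethyl in place of hydrogen on an aromatic carbon, meta to a large group, gives an at least 6.0-fold higher number from compound 3 to compound 4 (0.78 log units; beyond the scatter), so this position on the 2-phenylethenyl group is not silent: a change confined to one aromatic carbon moves the number beyond the scatter. Earlier steps exchanged the whole group on the carbonyl carbon and none was large, whereas the 2-(3-(trifluoromethyl)phenyl)ethenyl group gives an at least 17-fold higher number from compound 2 to compound 4 (1.23 log units; beyond the scatter) and an at least 30-fold higher number from compound 1 to compound 4 (1.48 log units; beyond the scatter), both large. Compound 4 carries a limit of the assay and not a number, so all three steps are read as bounds: the limit of > 1400000 nM in this assay, at which 1 of the 4 values shown sits.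

The compounds shown leave open whether fluorine, methoxy or a carboxylic acid on the same aromatic carbon would shift the number as trifluoromethyl does, or whether the shift is specific to trifluoromethyl. They also leave open whether trifluoromethyl on the phenyl ring of the phenoxymethyl group in compound 2 would give a comparable step, or whether the step depends on the 2-phenylethenyl group.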